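Calpain-2 inhibitors: varying the cap on the leucine amide

This account rests on a few compounds, and the source may have more. Where it says the series, first, only, none or still open, it means among the compounds named here.

Measured so far:
compound 1 `CCCCOC(=O)C(=O)C(CC)NC(=O)C(CC(C)C)NC(=O)OCc1ccccc1` — 400 nM
compound 2 `CCOC(=O)C(=O)C(CC)NC(=O)C(CC(C)C)NC(=O)CCc1ccccc1` — 1200 nM
compound 3 `CCOC(=O)C(=O)C(CC)NC(=O)C(CC(C)C)NC(=O)CCCCc1ccccc1` — 1900 nM

All numbers come from an assay on isolated protein (Oryctolagus cuniculus) for inhibition of Calpain-2 catalytic subunit (Homo sapiens), at pH 8.0; a higher number here means a weaker inhibitor, a lower number a stronger inhibitor. Compound 2 stands second highest of the three; the step of a 1.6-fold higher number from compound 2 to compound 3 (0.20 log units; within the scatter) is within the scatter, so compounds 2 and 3 are not separated. Compound 1 differs from compound 2 in more than one place and shows a lower number, beyond the scatter.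

Compound 4 `CCOC(=O)C(=O)C(CC)NC(=O)C(CC(C)C)NC(=O)C(CC)Oc1ccccc1` carries the change (1-phenoxypropyl in place of phenethyl on a carbonyl carbon). Among the measured compounds shown here, no measured step covers this change directly. For the measured compounds named here, the only step at the same position, a 1.6-fold higher number from compound 2 to compound 3 (0.20 log units; within the scatter), shows that lengthening the cap chain left this assay unchanged within scatter. For compound 4 the expected step is therefore none beyond the scatter, no change at the digits printed from compound 2 to compound 4 (within the scatter). Compound 4 is estimated at 1200 nM, with a range of 400 nM to 3600 nM.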

Compound 4, inhibition constant: 1400 nM
Compound 4: the middle estimate sits 1.2-fold (0.07 log units) below what was measured, within the range that was stated.
By their numbers in this assay, from the lowest: compound 1; then compounds 2, 4 and 3 (each within the scatter of the next).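

With 1-phenoxypropyl in place of phenethyl on the carbonyl carbon, this assay shows a 1.2-fold higher number from compound 2 to compound 4 (0.07 log units; within the scatter) and, against the 4-phenylbutyl cap, a 1.4-fold lower number from compound 3 to compound 4 (0.13 log units; within the scatter). Compounds 2, 3 and 4 therefore remain unseparated, and this position now shows no response beyond the scatter to a cap carrying an ether oxygen and a hydrogen-bond acceptor, as well as to chain length. No supporting data bear on why these caps remain unseparated.

Going by these compounds, whether an amine or a carboxylic acid on the cap would separate from these compounds remains open. On these data alone, compound 1 differs from them in more than one place, so the source of its lower number also remains open.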